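The compounds below may be only part of what the source reports. "The series", "measured", "known", "first", "only" and "open" are said of these compounds alone.

In a functional assay on KB cells (Homo sapiens) for inhibition (a lower number here means a stronger inhibitor, a higher number a weaker inhibitor), compound 1 `Clc1cc(Cl)c2[nH]c(Cl)nc2c1` gives > 100000 nM, which is a limit of the assay and not a number. Going by the values given here, compound 2 `OC[C@H]1OC(n2c(Br)nc3c(Cl)cc(Cl)cc32)[C@H](O)[C@@H]1O` reads 150000 nM, the only true number so far, so its standing cannot yet be ranked. Compound 3 `OC[C@H]1OC(n2c(S)nc3c(Cl)cc(Cl)cc32)[C@H](O)[C@@H]1O` carries sulfanyl in place of bromo on an aromatic carbon, between two ring nitrogen atoms: sulfanyl in place of bromo on an aromatic carbon. Among the compounds with values here, no measured step informs this change in this assay, so no shift beyond the scatter is expected. The estimated move is a 1.3-fold lower number from compound 2 to compound 3 (0.10 log units; within the scatter). For compound 3 the expected value is 120000 nM, with an estimated range of 40000 nM to 350000 nM.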

Compound 3, half-maximal inhibitory concentration: > 300000 nM
Compound 3: a limit, no number (the forecaster's own chance of this, stated with the estimate: 50%); middle value at least 2.5-fold (0.39 log units) from the limit.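

In this assay, sulfanyl in place of bromo on an aromatic carbon, between two ring nitrogen atoms, gives an at least 2.0-fold higher number from compound 2 to compound 3 (0.30 log units; that floor lies within the scatter). This swap brings no gain in inhibition, although no loss is established given that floor. The true size of the step stays unfixed because the reading for compound 3 is a limit and not a number: the limit of > 300000 nM in this assay, at which 1 of the 3 values shown sits.

As far as these compounds go, whether an amine or a methoxy group at this position would lower the number remains open. Also open, from the compounds shown here alone, is whether any group here brings the series clear of the weak end of this assay.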